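Trading a Chloro for Hydrogen on a Shared Core

The source may hold more compounds than are shown below. What is called first, only, known or untested is meant among the compounds shown, and "the series" means these compounds.

Compound 1 `ClCc1ccc(Cn2cnc3c(Cl)ncnc32)cc1`, compound 2 `ClCc1ccc(Cn2cnc3nc(Cl)nc(Cl)c32)cc1` and compound 3 `ClCc1ccc(Cn2cnc3c(Cl)nc(Cl)nc32)cc1` were tested in a functional assay on SK-MEL-5 cells (Homo sapiens) for cytotoxicity, read by sulforhodamine B assay, with a stated time of 48 h; a higher number here means a weaker inhibitor of growth, a lower number a stronger inhibitor of growth. In this assay compound 1 gives 3230 nM, compound 2 gives 2450 nM and compound 3 gives 6460 nM. Compound 1 arises from compound 3 through (hydrogen in place of chloro on an aromatic carbon), a change that made a 2.0-fold lower number from compound 3 to compound 1 (0.30 log units; within the scatter). The difference between the cores of compound 2 and compound 3 is not broken down here. Compound 4 `ClCc1ccc(Cn2cnc3ncnc(Cl)c32)cc1` is not yet measured; it arises from compound 2 through (hydrogen in place of chloro on an aromatic carbon), the same change at the same place. Resting on that earlier step a 2.0-fold lower number from compound 3 to compound 1 (0.30 log units; within the scatter) seen once in this assay, the expected step is a 1.8-fold lower number from compound 2 to compound 4 (0.24 log units; within the scatter). Compound 4 is therefore estimated at 1400 nM in this assay, with a likely range from 600 nM to 3500 nM.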

Compound 4, concentration for 50% growth inhibition: 2810 nM
Compound 4: middle estimate off by 2.0-fold (0.30 log units), on the low side; low and high end bracket the measured number.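

In this assay, putting hydrogen in place of the chloro gives a 1.1-fold higher number from compound 2 to compound 4 (0.06 log units; within the scatter), so on this core the swap has no effect that can be told from the usual scatter. Set beside the earlier step, the two cores cannot be told apart: the same change on two cores in this assay, a 2.0-fold lower number (0.30 log units; within the scatter) from compound 3 to compound 1 and a 1.1-fold higher number (0.06 log units; within the scatter) from compound 2 to compound 4, 2.3-fold (0.36 log units) apart, within the scatter of two such steps. This shows no sign that the change behaves differently on these two cores, but two steps within the scatter do not fix its size or show that it would behave alike on any other core.

The compounds shown leave open whether an amine, a methoxy group or a longer chain in place of the chloro would shift the number beyond the scatter.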